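Dropping a Methoxy Group from a Weak Methyltransferase Inhibitor

The source may hold more compounds than are shown below. What is called first, only, known or untested is meant among the compounds shown, and "the series" means these compounds.

Of the compounds shown here, two have so far been tested in an assay for inhibition of histone-lysine N-methyltransferase, H3 lysine-79 specific (Homo sapiens), read by scintillation counting, with stated times of 15 min and 60 min, in the presence of a further agent that is not named here; on this read-out lower numbers stand for stronger inhibition and higher numbers for weaker inhibition. Compound 1 `C(=C/c1nn2c(-c3ccncc3)nnc2s1)\c1ccco1` gives 13700 nM. Compound 2 `COc1ccccc1-c1nnc2sc(/C=C/c3ccco3)nn12` carries a methoxy-bearing phenyl ring on the shared core, and in this assay compound 2 gives 9700 nM. That is the lowest of the two numbers on hand, but the gap to compound 1 lies within the usual scatter of repeated measurements, so the two compounds cannot be told apart on these data.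

Compound 3 `C(=C/c1nn2c(-c3ccccc3)nnc2s1)\c1ccco1` has not yet been measured. It differs from compound 2 in one place: hydrogen in place of methoxy on an aromatic carbon. Among the measured compounds shown here, no pair of measured compounds shows what removing this group does, so the step has to be judged from the general picture: both measured compounds sit in the same weak range, and no measured step singles out the methoxy group. The step of a 1.2-fold higher number from compound 2 to compound 3 (0.09 log units; within the scatter) is expected to be small, at most a slight move toward a higher number, and most likely not beyond the scatter. Compound 3 is estimated at 12000 nM, with a range from 5000 nM to 30000 nM.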

Compound 3, half-maximal inhibitory concentration: 7010 nM
Compound 3: middle estimate off by 1.7-fold (0.23 log units), on the high side; measured number inside the range.
By their numbers in this assay, from the lowest: compounds 3, 2 and 1 (each within the scatter of the next).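

In this assay, replacing methoxy with hydrogen gives a 1.4-fold lower number from compound 2 to compound 3 (0.14 log units; within the scatter), so this first direct pair shows that the methoxy group on this phenyl ring, ortho to a large group, can be removed without a difference that stands out from the scatter. The second pair, with phenyl in place of pyridin-4-yl, gives a 2.0-fold lower number from compound 1 to compound 3 (0.29 log units; within the scatter), so on these data the two aromatic rings cannot be told apart either, although they occupy the same place on the shared core. No accompanying measurement bears on these results, so they can be described but not explained.

From the compounds shown here alone, with hydrogen, methoxy, and a pyridin-4-yl ring in place of phenyl all falling within the scatter, it remains open whether any change at this place can move the number beyond it. An amine or a carboxylic acid on the phenyl ring, or a longer chain such as ethoxy in place of methoxy, would test this, and the effect of changes elsewhere on the shared core is also still unknown.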